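The source may report more compounds than this note shows. Statements on the series, on what has been measured and on what is new or still open speak of the compounds shown alone.

Compound 1 `COc1cc2nc(N3CCN(C(=O)COc4ccccc4)CC3)nc(N)c2cc1OC` — 12.6 nM
Compound 2 `COc1cc2nc(N3CCN(/C(S)=N/C4CCCCC4)CC3)nc(N)c2cc1OC` — 5.37 nM

In an assay for binding affinity to Adrenergic receptor alpha-1 (Rattus norvegicus) (on this read-out higher numbers stand for weaker inhibition and lower numbers for stronger inhibition), compound 1 gives 12.6 nM, while compound 2 gives 5.37 nM. Compound 2 therefore holds the lowest number of the two, set apart from compound 1 by the step of a 2.3-fold lower number from compound 1 to compound 2 (0.37 log units; beyond the scatter). Compound 3 `COc1cc2nc(N3CCN(/C(S)=N/c4ccc(NC(=S)N5CC5)cc4)CC3)nc(N)c2cc1OC` is built from compound 2 by one change: a group of 12 heavy atoms (9 carbon, 2 nitrogen, 1 sulfur; one three-membered non-aromatic ring with 1 hetero atom, one six-membered aromatic ring of carbon only) in place of a group of 6 heavy atoms (6 carbon; one six-membered non-aromatic ring of carbon only), on a double-bonded nitrogen. Among the compounds with values here, only one measured step exists, a 2.3-fold lower number from compound 1 to compound 2 (0.37 log units; beyond the scatter), and it swapped a whole group on an amine nitrogen in a ring, not on the double-bonded nitrogen changed here, so it bears on the present step only loosely. With no measured change at this position, no direction can be read from the data. The number for compound 3 in this assay is expected to stay close to compound 2, with the step of a 1.2-fold higher number from compound 2 to compound 3 (0.08 log units; within the scatter) as the estimate. Compound 3 is estimated at 6.5 nM, within a range of 1.5 nM to 28 nM.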

Compound 3, half-maximal inhibitory concentration: 97.7 nM
The estimate for compound 3 lay 15-fold (1.18 log units) below the measured number, and the stated range ends below it.
By their numbers in this assay, from the lowest: compound 2; then compound 1; then compound 3.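

The double-bonded nitrogen proves to be a position that responds strongly: in this assay, replacing cyclohexyl with the larger group carrying a six-membered aromatic ring and a three-membered ring with one hetero atom gives an 18-fold higher number from compound 2 to compound 3 (1.26 log units; beyond the scatter). This step is larger than a 2.3-fold lower number from compound 1 to compound 2 (0.37 log units; beyond the scatter), which was made on an amine nitrogen in a ring, so a large group on the double-bonded nitrogen is not simply tolerated here. No measurement at hand accounts for the rise in the number.

The entering group differs from cyclohexyl in several parts at once, and the compounds shown cannot tell which part matters: the aromatic ring, the three-membered ring or the link between them. A plain phenyl group on the same nitrogen would begin to separate these parts.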